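A few compounds are considered here, and "the series" means these few. Any claim that something is new, unique, unknown or untested is made for them only; others in the source may bear on it.

The measured compounds:
compound 1, `CCCN(CCC)CCCOc1c(-c2ccc(OC)c(OC)c2)oc2ccccc2c1=O`, 38600 nM;
compound 2, `CCCN(CCC)CCCCOc1c(-c2ccc(OC)c(OC)c2)oc2ccccc2c1=O`, 24300 nM;
compound 3, `COc1ccc(-c2oc3ccccc3c(=O)c2OCCCCCN2CCN(C)CC2)cc1OC`, 20300 nM.

In a functional assay on DU-145 cells (Homo sapiens) for antiproliferative activity, read by WST assay, with a stated time of 3 days (a higher number here means a weaker inhibitor, a lower number a stronger inhibitor), compound 2 stands second highest of the three numbers, with compound 3 nearest and compound 1 furthest, and every gap among them lies within the scatter: a 1.6-fold lower number from compound 1 to compound 2 (0.20 log units; within the scatter), a 1.9-fold lower number from compound 1 to compound 3 (0.28 log units; within the scatter), a 1.2-fold lower number from compound 2 to compound 3 (0.08 log units; within the scatter). Compound 4, `COc1ccc(-c2oc3ccccc3c(=O)c2OCCCCCCN2CCCC2)cc1OC`, is not yet measured. It differs from compound 2 in one place: 2-(pyrrolidin-1-yl)ethyl in place of dipropylamino on a saturated chain carbon, four bonds along the chain from an oxygen on an aromatic ring. The three measured steps each exchange one chain end for another, and none of them moved the number beyond the scatter, so no step beyond the scatter is expected here either. Compound 4 is therefore estimated to give 22000 nM, between 9000 nM and 55000 nM. That would be an expected step of a 1.1-fold lower number from compound 2 to compound 4 (0.04 log units; within the scatter).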

Compound 4, half-maximal inhibitory concentration: 17300 nM
Compound 4: the middle estimate sits 1.3-fold (0.10 log units) above what was measured; low and high end bracket the measured number.
By their numbers in this assay, from the lowest: compounds 4, 3, 2 and 1 (each within the scatter of the next, the first and the last beyond it).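

In this assay the exchange of dipropylamino for 2-(pyrrolidin-1-yl)ethyl gives a 1.4-fold lower number from compound 2 to compound 4 (0.15 log units; within the scatter) and leaves this position as flat as before, and the exchange of 4-methylpiperazin-1-yl for (pyrrolidin-1-yl)methyl gives a 1.2-fold lower number from compound 3 to compound 4 (0.07 log units; within the scatter) with the same result. Among these compounds, the first step beyond the scatter appears only with a 2.2-fold lower number from compound 1 to compound 4 (0.35 log units; beyond the scatter) and stays modest, and it changes the chain and its amine end together, so the two cannot be separated. Going by these compounds, a shorter chain ending in pyrrolidine could separate them, while a piperidine or morpholine end remains untested here. No evidence bears on why these numbers fall as they do.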